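Aryl amide variation on the shared core

The source may report more compounds than this note shows. Statements on the series, on what has been measured and on what is new or still open speak of the compounds shown alone.

Compound 2 `O=C(O)CCc1ccc(OCc2nnc(C(=O)Nc3ccc(F)cc3)s2)cc1` gives 6640 nM in a functional assay on CHO cells for agonist activity at Free fatty acid receptor 1 (Homo sapiens), read by calcium flux (a higher number here means that more compound is needed for the effect, a lower number that less compound is needed), the highest of the two numbers recorded so far. For the measured compounds named here, its nearest neighbour is compound 1 `O=C(O)CCc1ccc(OCc2nnc(C(=O)Nc3ccccc3F)s2)cc1`, which gives 580 nM in this assay; the only measured step is an 11-fold higher number from compound 1 to compound 2 (1.06 log units; beyond the scatter). Compound 3 `COc1cccc(NC(=O)c2nnc(COc3ccc(CCC(=O)O)cc3)s2)c1` is not yet measured; it differs from compound 2 by 3-methoxyphenyl in place of 4-fluorophenyl on an amide-type nitrogen. Going by the values given here, no measured step covers this particular exchange: the one step on record concerns a fluorine moved within the phenyl ring, not a methoxy group, so it bears on the new change only in showing that the aryl substituent pattern on the amide nitrogen can shift this assay by a large amount. A step of moderate size in either direction is therefore possible, with a slight lean toward a lower number, expected as a 2.7-fold lower number from compound 2 to compound 3 (0.42 log units; beyond the scatter). Compound 3 is estimated at 2500 nM, with a range from 500 nM to 12000 nM.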

Compound 3, half-maximal effective concentration: 4680 nM
Compound 3: the middle estimate sits 1.9-fold (0.27 log units) below what was measured; measured number inside the range.
By their numbers in this assay, from the lowest: compound 1; then compounds 3 and 2 (each within the scatter of the next).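

In this assay the exchange of 4-fluorophenyl for 3-methoxyphenyl on the amide-type nitrogen gives a 1.4-fold lower number from compound 2 to compound 3 (0.15 log units; within the scatter) and so does not separate these two compounds, even though the entering group differs in both its substituent and that substituent's place on the ring. Set against 2-fluorophenyl, the same 3-methoxyphenyl group gives an 8.1-fold higher number from compound 1 to compound 3 (0.91 log units; beyond the scatter) and this leaves compound 1 apart from both other aryl amides, with the lowest number of the three. No evidence on hand explains these differences.

The compounds shown do not tell whether the 2-fluorophenyl result depends on fluorine itself or on its place on the ring. As far as these compounds go, it also remains open how an unsubstituted phenyl group, or a chlorine or nitrile on the phenyl ring, would read in this assay on this shared core.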